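The source may hold more compounds than are shown below. What is called first, only, known or untested is meant among the compounds shown, and "the series" means these compounds.

In a functional assay on EA.hy 926 cells (Homo sapiens) for cytotoxicity, read by MTT assay, with stated times of 24 h and 12 h, tested at 100 uM (on this read-out lower numbers stand for a weaker effect and higher numbers for a stronger effect at the one concentration tested), compound 2 `Cc1nc(C)c(C(=O)Oc2ccccc2/C=C/C(=O)O)nc1C` gives 80.1%, the highest of the three numbers measured. Compound 1 `CCOC(=O)/C=C/c1ccccc1OC(=O)c1nc(C)c(C)nc1C` gives 40.9%, and compound 3 `CCOC(=O)/C=C/c1cc(OC)c(OC(=O)c2nc(C)c(C)nc2C)c(OC)c1` gives -47%. Going by the values given here, the only step between neighbours that differ in a single place, hydrogen in place of ethyl on an oxygen next to a carbonyl group, was a number 39.2 percentage points higher from compound 1 to compound 2 (beyond the scatter). Compound 4 `COc1ccc(/C=C/C(=O)O)c(OC(=O)c2nc(C)c(C)nc2C)c1` differs from compound 2 by methoxy in place of hydrogen on an aromatic carbon. Among the compounds with values here, no measured step changes a methoxy group alone; the only hint is that compound 3, which carries two methoxy groups and the ethyl ester, shows a far lower number than compound 1. The step of a number 40.1 percentage points lower from compound 2 to compound 4 (beyond the scatter) is therefore expected to be a fall, with wide uncertainty. Compound 4 is estimated at 40%, between -5% and 85%.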

Compound 4, a percentage reported as activity, at one concentration (the size of the read-out at that concentration, not a potency): 18%
Compound 4: middle estimate off by 22 percentage points, on the high side; the range from low to high includes it.
By their numbers in this assay, from the lowest: compound 3; then compound 4; then compound 1; then compound 2.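

Methoxy in place of hydrogen on an aromatic carbon, para to a 2-carboxyethenyl group, gives a number 62.1 percentage points lower from compound 2 to compound 4 (beyond the scatter) in this assay and is the first measured step to change this group alone. A single small addition at this place is therefore enough to lower the number sharply, even with the free carboxylic acid kept. Nothing available explains this fall. As far as these compounds go, whether a hydroxy group or an amine at this place would lower the number as well stays open. So does whether methoxy here would have the same effect in the ethyl ester, compound 1.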